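Trimming the Last Methyl on the Pyrazolyl Amide

The source may report more compounds than this note shows. Statements on the series, on what has been measured and on what is new or still open speak of the compounds shown alone.

For the measured compounds named here, compound 2 `Cc1cc(C(=O)N2CCc3c(sc(NCc4ccccc4)c3C#N)C2)[nH]n1` stands as the stronger of the two compounds measured so far. In a functional assay on Chem-3 cells for antagonist activity at metabotropic glutamate receptor 1 (Homo sapiens), read by fluorescence and calcium flux (on this read-out lower numbers stand for stronger inhibition and higher numbers for weaker inhibition), compound 2 gives 1420 nM, whereas compound 1 `CC(C)c1cc(C(=O)N2CCc3c(sc(NCc4ccccc4)c3C#N)C2)[nH]n1` gives 43200 nM. Going by the values given here, the one step joining them, a 30-fold lower number from compound 1 to compound 2 (1.48 log units; beyond the scatter), shows that shrinking the group on the five-membered aromatic ring with 2 nitrogen went together with a much lower number.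

Compound 3 `N#Cc1c(NCc2ccccc2)sc2c1CCN(C(=O)c1ccn[nH]1)C2` takes this shrinking one stage further: hydrogen in place of methyl on an aromatic carbon. Among the compounds with values here, only a single measured step bears on such a change, a 30-fold lower number from compound 1 to compound 2 (1.48 log units; beyond the scatter), and it was large. Whether removing the remaining carbon at this position carries the same trend onward cannot be read from two numbers; it is equally possible that methyl already marks the point beyond which nothing more is gained. The expected step is therefore a 1.8-fold lower number from compound 2 to compound 3 (0.25 log units; within the scatter), toward a lower number but of modest size, and the uncertainty around it is wide. Compound 3 is estimated at 800 nM, within a range from 200 nM to 3000 nM.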

Compound 3, half-maximal inhibitory concentration: 1090 nM
For compound 3 the middle estimate is 1.4-fold (0.13 log units) below the measured one, and the stated range covers the measured number.
By their numbers in this assay, from the lowest: compounds 3 and 2 (each within the scatter of the next); then compound 1.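

In this assay, removing the last carbon at this position gives a 1.3-fold lower number from compound 2 to compound 3 (0.11 log units; within the scatter), so on this read-out the 3-methyl-1H-pyrazol-5-yl and 1H-pyrazol-5-yl amides cannot be told apart, and the shrinking trend seen with the first step does not carry on in any measurable way. Going all the way from isopropyl to hydrogen gives a 40-fold lower number from compound 1 to compound 3 (1.60 log units; beyond the scatter), so among these three compounds the large change comes with the loss of isopropyl, while methyl and hydrogen sit together at the low end. Nothing measured here explains why isopropyl gives so much higher a number.

With only hydrogen, methyl and isopropyl shown at this position, it remains open whether an ethyl group would behave like methyl or like isopropyl, and so how quickly the number climbs as the group grows. From the compounds shown here alone, it is equally open whether a group of a different kind here, such as an amine or a chlorine atom, would bring the number lower than compound 2 and compound 3 do.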